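The source may report more compounds than this note shows. Statements on the series, on what has been measured and on what is new or still open speak of the compounds shown alone.

Series notes, compound 1 to compound 4. The shared core is that of compound 1 `COc1cc(C(=O)/C=C/c2ccc(OCCCC(=O)NCCCNCCCCN)cc2)cc(OC)c1OC`, a chalcone carrying a polyamine-terminated ether chain on one aryl ring. In a functional assay on HCT-116 cells (Homo sapiens) for antiproliferative activity, read by MTT assay, with a stated time of 48 h (a higher number here means a weaker inhibitor, a lower number a stronger inhibitor), compound 1 reaches only the limit > 100000 nM, so it stands at the weak end of what the assay can report. Two measured analogues carry the ether chain on a different ring position of the core: compound 2 `COc1ccc(/C=C/C(=O)c2cc(OC)c(OC)c(OC)c2)cc1OCCCC(=O)NCCCNCCCCNCCN` gives 55800 nM in this assay, and compound 3 `COc1ccc(/C=C/C(=O)c2cc(OC)c(OC)c(OC)c2)cc1OCCCC(=O)NCCCCN(CCCN)CCCCN` gives 73600 nM. Within the data shown here, the only measured single-point step, a 1.3-fold higher number from compound 2 to compound 3 (0.12 log units; within the scatter), is a rearrangement within the polyamine tail and leaves the number essentially where it was.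

Compound 4 `COc1cc(C(=O)/C=C/c2ccc(OCCCC(=O)NCCCCNCCCN)cc2)cc(OC)c1OC` differs from compound 1 by ((3-aminopropyl)amino)methyl in place of (4-aminobutyl)amino on a saturated chain carbon, three bonds along the chain from an amide-type nitrogen, again a rearrangement of the polyamine tail. Among the measured compounds shown here, the step from compound 2 to compound 3 is the closest precedent and was within the scatter, so no step beyond the scatter is expected in this assay from compound 1 to compound 4. Since compound 1 sits at the limit of > 100000 nM in this assay, at which 1 of the 3 values shown sits, compound 4 is expected to remain near or beyond that limit; the expectation is 120000 nM, with a range of 40000 nM to 400000 nM, meaning a step that the limit leaves unreadable from compound 1 to compound 4.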

Compound 4, half-maximal inhibitory concentration: 20000 nM
Compound 4: the middle estimate sits 6.0-fold (0.78 log units) above what was measured; the whole stated range lies above it.
By their numbers in this assay, from the lowest: compound 4; then compounds 2 and 3 (each within the scatter of the next). At a limit, above all of these: compound 1.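

In this assay, ((3-aminopropyl)amino)methyl in place of (4-aminobutyl)amino, three bonds along the chain from an amide-type nitrogen, gives an at least 5.0-fold lower number from compound 1 to compound 4 (0.69 log units; beyond the scatter). The two tails have the same atoms, joined differently, so for this pair the arrangement of the tail alone moves the number beyond the scatter, unlike the different tail rearrangement in a 1.3-fold higher number from compound 2 to compound 3 (0.12 log units; within the scatter). Compound 1 is reported only as a limit, so the full size of the step stays unread: the limit of > 100000 nM in this assay, at which 1 of the 4 values shown sits.

From the compounds shown here alone, it remains open whether the same tail change would move the number when the ether chain sits at the ring position carried by compound 2 and compound 3. Also open, going by these compounds, is how a longer chain, or a carboxylic acid in place of the terminal amine, would read on the tail of compound 4.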